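The source may hold more compounds than are shown below. What is called first, only, known or untested is meant among the compounds shown, and "the series" means these compounds.

Values in a functional assay on KB cells (Homo sapiens) for cytotoxicity (a higher number here means a weaker inhibitor, a lower number a stronger inhibitor), so far:
compound 1 (`COC(=O)c1ccc(C(=O)Nc2cccc3c2N(S(=O)(=O)c2ccc(OC)cc2)CC3)cc1`): 376 nM
compound 2 (`COc1ccc(S(=O)(=O)N2CCc3cccc(NC(=O)c4ccc([N+](=O)[O-])cc4)c32)cc1`): 102 nM
compound 3 (`COc1ccc(S(=O)(=O)N2CCc3cccc(NC(=O)c4ccc(F)cc4)c32)cc1`): 93 nM

Compound 3 sits at the low end of these numbers, level with compound 2 (a 1.1-fold lower number from compound 2 to compound 3 (0.04 log units; within the scatter)), and clearly under compound 1. The next compound, compound 4 (`COc1ccc(S(=O)(=O)N2CCc3cccc(NS(=O)(=O)c4ccccc4)c32)cc1`), has phenylsulfonyl in place of (4-fluorophenyl)carbonyl on a nitrogen on an aromatic ring.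

The measured steps bear on this change only indirectly. Each exchanges one group on an aromatic carbon and leaves the carbonyl in place. The two that go beyond the scatter are modest (a 3.7-fold lower number from compound 1 to compound 2 (0.57 log units; beyond the scatter); a 4.0-fold lower number from compound 1 to compound 3 (0.61 log units; beyond the scatter)). Within the data shown here, no measured compound carries a sulfonyl at this nitrogen, so the data do not fix the direction, and any lean is a judgement. Since this change replaces the whole group rather than one substituent, a step of at least the modest size seen from compound 1 to compound 3 (a 4.0-fold lower number from compound 1 to compound 3 (0.61 log units; beyond the scatter)) seems reasonable, and a higher number is thought more likely than a lower one. The expected change in this assay is thus a modest rise (a 3.2-fold higher number from compound 3 to compound 4 (0.51 log units; beyond the scatter)). Compound 4 is estimated at 300 nM (expected range 80 nM to 1300 nM).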

Compound 4, half-maximal inhibitory concentration: 650 nM
The estimate for compound 4 lay 2.2-fold (0.34 log units) below the measured number; low and high end bracket the measured number.
By their numbers in this assay, from the lowest: compounds 3 and 2 (each within the scatter of the next); then compounds 1 and 4 (each within the scatter of the next).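

In this assay, among these compounds, the nitrogen on the aromatic ring is now varied for the first time, and replacing (4-fluorophenyl)carbonyl with phenylsulfonyl gives a 7.0-fold higher number from compound 3 to compound 4 (0.84 log units; beyond the scatter). The earlier steps shown here had kept the carbonyl and changed only a group on an aromatic carbon, so this step shows that the group on this nitrogen also matters in this assay, and that in this one pair the sulfonyl goes with the higher number. No evidence is available to explain the rise.

The step changes two things at once, since the carbonyl gives way to the sulfonyl and the fluoro leaves the aromatic ring, so the shown compounds do not separate the share of each; a (4-fluorophenyl)sulfonyl group on this nitrogen would bear directly on that. As far as these compounds go, it also remains open how this nitrogen behaves with groups of another kind, such as methylsulfonyl, an acetyl group or a longer alkyl chain, and whether a nitro or methoxycarbonyl group on the phenylsulfonyl ring would shift the number as it does on the carbonyl series.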